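This account rests on a few compounds, and the source may have more. Where it says the series, first, only, none or still open, it means among the compounds named here.

Measured so far in a functional assay on K562 cells (Homo sapiens) for inhibition, read by trypan blue exclusion, with a stated time of 72 h; a higher number here means a weaker inhibitor, a lower number a stronger inhibitor:

compound 1, `Cn1c(=O)c(S(=O)(=O)c2ccc(F)cc2F)cc2cnc(Nc3ccc4sccc4c3)nc21`, gives 500 nM
compound 2, `Cc1ccc(S(=O)(=O)c2cc3cnc(Nc4ccc5[nH]ccc5c4)nc3n(C)c2=O)cc1`, gives 750 nM
compound 3, `Cn1c(=O)c(S(=O)(=O)c2ccc(F)cc2)cc2cnc(Nc3cccc4[nH]ccc34)nc21`, gives 750 nM

Compound 1 carries the lowest of the three numbers, but its gaps to compound 2 and to compound 3 both lie within the usual scatter of this assay, so the three cannot be separated on these data and none is called the stronger inhibitor. Going by the values given here, no pair of measured compounds differs in only one place, so no single-point step is available to guide an estimate.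

Compound 4, `Cn1c(=O)c(S(=O)(=O)c2ccc(F)cc2F)cc2cnc(Nc3ccc4c(c3)C(=O)C(=O)N4)nc21`, is the next compound for this assay. It differs from compound 1 as follows: a group of 11 heavy atoms (8 carbon, 1 nitrogen, 2 oxygen; one five-membered non-aromatic ring with 1 hetero atom, one six-membered aromatic ring of carbon only) in place of a group of 9 heavy atoms (8 carbon, 1 sulfur; one five-membered aromatic ring with 1 hetero atom, one six-membered aromatic ring of carbon only), on a nitrogen on an aromatic ring. Among the compounds with values here, with no matching step among the measured compounds, the size and direction of the change cannot be drawn from a precedent; a modest step is expected, possibly toward a somewhat higher number, but one that may well not exceed the scatter.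

The expected step is a 1.4-fold higher number from compound 1 to compound 4 (0.15 log units; within the scatter). Compound 4 is expected to give 700 nM, with a range from 250 nM to 2000 nM.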

Compound 4, half-maximal inhibitory concentration: 30000 nM
Beside the measured number, compound 4's estimate is 43-fold (1.63 log units) below it; the whole stated range lies below it.
By their numbers in this assay, from the lowest: compounds 1, 2 and 3 (each within the scatter of the next); then compound 4.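

In this assay, the group on this nitrogen on an aromatic ring now proves able to shift the number far beyond the scatter: replacing 1-benzothiophen-5-yl with the group holding a five-membered non-aromatic ring gives a 60-fold higher number from compound 1 to compound 4 (1.78 log units; beyond the scatter). Going by these compounds alone, as this is the first step that differs in one place, it shows that this position does not accept every two-ring group while the rest of compound 1 stays unchanged. No measurement shown accounts for the size of this step.

One step cannot separate the loss of the five-membered aromatic ring with its sulfur from the gain of the two carbonyls and the ring nitrogen with its hydrogen. From the compounds shown here alone, it also remains open whether a 1-benzothiophen-5-yl group carrying an amine or a carboxylic acid would stay near compound 1 or move toward compound 4.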